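The source may hold more compounds than are shown below. What is called first, only, known or untested is meant among the compounds shown, and "the series" means these compounds.

Measured compounds:
Compound 1 `Clc1ccc(Nc2nnc(Cc3c(Cl)cccc3Cl)o2)cc1Cl` gives > 100000 nM in a functional assay on MT2 cells (Homo sapiens) for cytotoxicity, read by MTT assay (on this read-out lower numbers stand for higher toxicity in this test and higher numbers for lower toxicity in this test), which is a limit of the assay rather than a number.
Compound 2 `Clc1ccc(Nc2nnc(Cc3c(Cl)cccc3Cl)o2)cc1` gives 20000 nM in this assay.

Among the compounds with values here, compound 2 is therefore the only compound with an actual number here; the other value is a limit. Within the data shown here, the one measured step, an at least 5.0-fold lower number from compound 1 to compound 2 (0.69 log units; beyond the scatter), shows that taking a chloro group off the aromatic ring went with a lower number, that is, more toxicity in this assay. Compound 3 `FC(F)(F)c1cc(Nc2nnc(Cc3c(Cl)cccc3Cl)o2)ccc1Cl` is now to be measured; it differs from compound 2 by trifluoromethyl in place of hydrogen on an aromatic carbon, so a substituent returns to the same aromatic carbon that lost its chloro group in the step from compound 1 to compound 2. Among the measured compounds shown here, that step is the only guide and it is at least modest in size, so a rise of the number, back toward the limit, is expected for compound 3, as a 2.5-fold higher number from compound 2 to compound 3 (0.40 log units; beyond the scatter). Compound 3 is thus estimated at 50000 nM, within a range of 15000 nM to 100000 nM.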

Compound 3, half-maximal cytotoxic concentration: 9000 nM
Beside the measured number, compound 3's estimate is 5.6-fold (0.74 log units) above it, outside the stated range (below it).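

Replacing hydrogen with trifluoromethyl at this aromatic carbon, ortho to a chloro group, gave a 2.2-fold lower number from compound 2 to compound 3 (0.35 log units; beyond the scatter) in this assay, so a substituent here does not by itself mean less toxicity. The identity of the group matters, as trifluoromethyl and chloro at this same carbon are far apart, with an at least 11-fold lower number from compound 1 to compound 3 (1.04 log units; beyond the scatter). The true size of that second step is unknown, since the entry for compound 1 is a limit: the limit of > 100000 nM in this assay, at which 1 of the 3 values shown sits.

Going by these compounds, whether the order seen here, with chloro giving the highest entry, hydrogen the middle one and trifluoromethyl the lowest, extends to other groups at this carbon stays open, for example a methoxy group, an amine or a carboxylic acid. These few compounds also cannot tell what about trifluoromethyl goes with the lower number.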